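Furan-Methylamine in Place of a Dimethylaminoethyl Chain

The source may hold more compounds than are shown below. What is called first, only, known or untested is meant among the compounds shown, and "the series" means these compounds.

Measured so far:
compound 1 `CCN(CCN(C)C)c1nc(=O)c2cc(C(F)(F)F)cc([N+](=O)[O-])c2s1` — 10600 nM
compound 2 `O=c1nc(N2CCC(c3ccccc3)CC2)sc2c([N+](=O)[O-])cc(C(F)(F)F)cc12` — 60 nM

Of the compounds shown here, two have been measured in a physicochemical assay for solubility, measured as kinetic solubility, at pH 7.4; on this read-out higher numbers stand for higher solubility and lower numbers for lower solubility. Compound 1 holds the higher of the two numbers; its nearest neighbour, compound 2, stands a long way below it, and that gap lies beyond the scatter of the measurement. Among the measured compounds shown here, no pair of measured compounds differs in only one place, so no single step between measured compounds can be read directly.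

Compound 3 `O=c1nc(NCc2ccco2)sc2c([N+](=O)[O-])cc(C(F)(F)F)cc12` has not yet been measured. It differs from compound 1 in one place: ((furan-2-yl)methyl)amino in place of (2-(dimethylamino)ethyl)(ethyl)amino on an aromatic carbon. The chain that leaves carries no ring; the group that enters carries one five-membered aromatic ring with one hetero atom and one hydrogen-bond donor.

On the numbers shown, compound 1 gives 10600 nM and compound 2 gives 60 nM; compound 3 is expected to fall between them, nearer the lower end. The estimated step of a 35-fold lower number from compound 1 to compound 3 (1.55 log units; beyond the scatter) is downward and beyond the scatter. Compound 3 is therefore estimated at 300 nM, with a range from 60 nM to 1500 nM.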

Compound 3, solubility: 1630 nM
For compound 3 the middle estimate is 5.4-fold (0.74 log units) below the measured one; measured number outside the range, above it.
By their numbers in this assay, from the lowest: compound 2; then compound 3; then compound 1.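

In this assay, among the compounds shown here, putting ((furan-2-yl)methyl)amino in place of (2-(dimethylamino)ethyl)(ethyl)amino on the aromatic carbon next to the ring nitrogen and next to the ring sulfur gives a 6.5-fold lower number from compound 1 to compound 3 (0.81 log units; beyond the scatter), the first change at this position that can be read on its own. The number at this position therefore responds to the group it carries, yet the ring-bearing, donor-bearing group leaves compound 3 at 1630 nM and so still above compound 2 at 60 nM in the order of the series. No measurement shown bears on why the number moves as it does.

The compounds shown leave open which part of the change matters, as the loss of the dimethylamino end, the gain of the furan ring and the gain of a hydrogen-bond donor all arrive together in this one step. Also open, from the compounds shown here alone, is whether a benzylamino group, a morpholine ring or a (2-(dimethylamino)ethyl)amino chain that keeps the amino hydrogen would stand nearer compound 1 or nearer compound 3 in this assay.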